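Replacing the benzyl phenyl with a thiazole in compound 4

A few compounds are considered here, and "the series" means these few. Any claim that something is new, unique, unknown or untested is made for them only; others in the source may bear on it.

In an in vitro ADME assay on microsomes from liver (Homo sapiens) for metabolic stability (a lower number here means slower removal, a higher number faster removal of the compound), compound 2 `O=C(COCc1ccccc1)N1CCN(c2ccc(Cl)cc2Cl)CC1` gives 450 mL.min-1.g-1. Among the three compounds measured, compound 2 has the second highest number. Its nearest neighbour is compound 3 `O=C(COCc1ccccc1)N1CCN(c2ccc(F)cc2Cl)CC1`, which gives 530 mL.min-1.g-1, and the step of a 1.2-fold higher number from compound 2 to compound 3 (0.07 log units; within the scatter) lies within the scatter. The furthest is compound 1 `O=C(COCc1ccccc1)N1CCN(c2cccc(Cl)c2)CC1`, which gives 310 mL.min-1.g-1; the step of a 1.5-fold higher number from compound 1 to compound 2 (0.16 log units; within the scatter) is also within the scatter, as is a 1.7-fold higher number from compound 1 to compound 3 (0.23 log units; within the scatter).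

Compound 4 `O=C(COCc1nccs1)N1CCN(c2ccc(Cl)cc2Cl)CC1` has not been measured. It differs from compound 2 in one place: 1,3-thiazol-2-yl in place of phenyl on a saturated chain carbon bound to an oxygen on a saturated carbon. Within the data shown here, all three measured steps changed the aryl group on the amine nitrogen in the ring, and none of them touched the benzyloxy end, so no measured step bears on this change. Those steps were all within the scatter, which shows that the three measured compounds sit close together. With nothing to anchor a direction, the expected step of a 1.1-fold lower number from compound 2 to compound 4 (0.03 log units; within the scatter) is none beyond the scatter. Compound 4 is therefore estimated at 420 mL.min-1.g-1 in this assay, with a range from 180 mL.min-1.g-1 to 950 mL.min-1.g-1.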

Compound 4, intrinsic clearance in microsomes: 80 mL.min-1.g-1
Beside the measured number, compound 4's estimate is 5.3-fold (0.72 log units) above it; the whole stated range lies above it.
By their numbers in this assay, from the lowest: compound 4; then compounds 1, 2 and 3 (each within the scatter of the next).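

In this assay, 1,3-thiazol-2-yl in place of phenyl gives a 5.6-fold lower number from compound 2 to compound 4 (0.75 log units; beyond the scatter), the only step shown that lies beyond the scatter; the changes to the aryl group on the amine nitrogen in the ring all stayed within it. So the group on a saturated chain carbon bound to an oxygen on a saturated carbon can shift this number in a way the earlier compounds gave no sign of, and here the swap replaces a six-membered aromatic ring of carbon only with a five-membered one holding nitrogen and sulfur. Nothing available explains why the number drops.

As far as these compounds go, it remains open whether the ring nitrogen, the sulfur or the smaller ring carries the step, which a thiophene or a pyridine at this position could help separate. From the compounds shown here alone, it is also open whether the step would hold with the 3-chlorophenyl of compound 1 or the 2-chloro-4-fluorophenyl of compound 3.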